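A few compounds are considered here, and "the series" means these few. Any claim that something is new, unique, unknown or untested is made for them only; others in the source may bear on it.

Measured compounds in a functional assay on HCT-116 cells (Homo sapiens) for antiproliferative activity, read by MTT assay, with a stated time of 48 h; on this read-out higher numbers stand for weaker inhibition and lower numbers for stronger inhibition:

- compound 1 `Cc1ccc(-n2nncc2CN2C(=O)C3(C(C#N)=C(N)Oc4c3c3nc5ccccc5nc3c3ccccc43)c3ccccc32)cc1C`, which gives only the limit of the assay, > 50000 nM.
- compound 2 `CCOc1ccccc1-n1nncc1CN1C(=O)C2(C(C#N)=C(N)Oc3c(N)cc4nc5ccccc5nc4c32)c2ccccc21`, which also gives only a limit, > 50000 nM.

Among the measured compounds shown here, compound 2 therefore stands at the edge of what this assay can report: its value is a limit rather than a number, and the one other value shown is a limit too, as the limit of > 50000 nM in this assay, at which 2 of the 2 values shown sit, records. No step between two measured compounds exists here, so no measured change in activity can be pointed to, and nothing in the shown values separates compound 1 from compound 2.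

Compound 3 `Cc1ccc(Cl)cc1-n1nncc1CN1C(=O)C2(C(C#N)=C(N)Oc3c(N)cc4nc5ccccc5nc4c32)c2ccccc21` has not yet been measured. It differs from compound 2 in one place: 5-chloro-2-methylphenyl in place of 2-ethoxyphenyl on an aromatic nitrogen. The rest of the molecule is kept unchanged.

With both measured values sitting at the limit, there is nothing to suggest that this change moves the compound into the range where a number is read. In this assay the expected step is a number no higher from compound 2 to compound 3 (the limit leaves the size open), that is, none beyond the usual scatter. Compound 3 is accordingly estimated at 50000 nM, within 15000 nM to 150000 nM, and most likely reported once more only as a limit.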

Compound 3, half-maximal inhibitory concentration: 37200 nM
Compound 3: middle estimate off by 1.3-fold (0.13 log units), on the high side, within the range that was stated.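

In this assay, compound 3 is the only one of the compounds shown that gives an actual number, 37200 nM, so a change at this position, on an aromatic nitrogen of the five-membered ring with three nitrogens, can bring a compound of this series into the range where the assay reads a value. Compound 2 gives only a limit of the assay, > 50000 nM. Exchanging 2-ethoxyphenyl for 5-chloro-2-methylphenyl gives an at least 1.3-fold lower number from compound 2 to compound 3 (0.12 log units; that floor lies within the scatter), but this is only a floor, so the change may be as small as ordinary scatter or considerably larger, and the data cannot tell which.

A firmer reading of this position is still missing, as most of the values shown give no number at all: the limit of > 50000 nM in this assay, at which 2 of the 3 values shown sit. Also open, going by these compounds, is whether the chlorine or the methyl of the new group matters more, and how a phenyl ring carrying an amine or a carboxylic acid at this position would read in this assay.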